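The source may hold more compounds than are shown below. What is called first, only, known or untested is meant among the compounds shown, and "the series" means these compounds.

For the measured compounds named here, in an assay on CHO cells with metabotropic glutamate receptor 2 (Homo sapiens) as the target, read by FLIPR (a lower number here means a smaller maximal response, a higher number a larger maximal response), compound 1 `Cn1c(CN2CCN(c3ccc(Cl)cc3F)CC2)nc2ccccc21` gives 69%, the lowest of the three numbers measured so far. Compound 3 `Cn1c(CN2CCN(c3nc4ccccc4s3)CC2)nc2ccccc21`, which carries a different aromatic group on the same amine nitrogen in a ring, gives 88% in this assay, a number beyond the scatter above compound 1; compound 2 `Cn1c(CN2CCC(c3ccc(Cl)cc3)CC2)nc2ccccc21` gives 91%, also beyond the scatter above compound 1, while compounds 2 and 3 lie within the scatter of each other. Compound 4 `Cn1c(CN2CCN(c3ccccn3)CC2)nc2ccccc21` has not yet been measured. It differs from compound 1 in one place: pyridin-2-yl in place of 4-chloro-2-fluorophenyl on an amine nitrogen in a ring. Given that compound 3 with another nitrogen-containing aromatic group at this position reaches 88%, the expected step of a number 13 percentage points higher from compound 1 to compound 4 (beyond the scatter) is upward and beyond the scatter. The estimate for compound 4 in this assay is 82%, with a range from 65% to 96%.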

Compound 4, largest response reached (Emax), in percent of the reference or control that the assay uses: 100%
The estimate for compound 4 lay 18 percentage points below the measured number; the whole stated range lies below it.
By their numbers in this assay, from the lowest: compound 1; then compounds 3, 2 and 4 (each within the scatter of the next, the first and the last beyond it).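

In this assay pyridin-2-yl in place of 4-chloro-2-fluorophenyl gives a number 31 percentage points higher from compound 1 to compound 4 (beyond the scatter) as a large step. For the compounds shown here, this is the first pair that differs in one place, and it shows that the maximal response changes with the aromatic group on this amine nitrogen while the rest of the structure stays the same. Nothing at hand accounts for the size of this step.

This pair cannot separate the gain of the ring nitrogen from the loss of the chlorine and fluorine. Plain phenyl or pyrimidin-2-yl at this position would bear on that question.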